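The source may report more compounds than this note shows. Statements on the series, on what has been measured and on what is new or still open speak of the compounds shown alone.

Measured in an in vitro ADME assay on microsomes from liver (Rattus norvegicus) for metabolic stability, read by LC-MS, tested at 1 uM; on this read-out higher numbers stand for fast clearance and lower numbers for slow clearance:
Compound 1 `COCCNS(=O)(=O)c1ccc(C)c(C#Cc2cc(Cl)ccc2OCC(=O)O)c1`: < 10 mL.min-1.g-1, a limit of the assay
Compound 2 `Cc1ccc(S(=O)(=O)NC(C)C)cc1C#Cc1cc(Cl)ccc1OCC(=O)O`: 12 mL.min-1.g-1
Compound 3 `Cc1ccc(S(=O)(=O)N(C)CC(C)C)cc1C#Cc1cc(Cl)ccc1OCC(=O)O`: 119 mL.min-1.g-1

Of the two actual numbers, the higher belongs to compound 3, at 119 mL.min-1.g-1. The nearest number lies with compound 2. Compound 4 `Cc1ccc(S(C)(=O)=O)cc1C#Cc1cc(Cl)ccc1OCC(=O)O` carries methyl in place of isobutyl(methyl)amino on a sulfonyl sulfur. Two measured steps change that same substituent: a 9.9-fold higher number from compound 2 to compound 3 (1.00 log units; beyond the scatter), and an at least 11-fold higher number from compound 1 to compound 3 (1.07 log units; beyond the scatter). Both rise on arrival at isobutyl(methyl)amino, so removing that group is expected to give a large fall in this assay, though neither step installs methyl. The expected change is a 12-fold lower number from compound 3 to compound 4 (1.08 log units; beyond the scatter). The estimate for compound 4 is 10 mL.min-1.g-1, with an expected range of 4 mL.min-1.g-1 to 30 mL.min-1.g-1. A limit instead of a number is quite possible.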

Compound 4, intrinsic clearance in microsomes: 18 mL.min-1.g-1
Beside the measured number, compound 4's estimate is 1.8-fold (0.26 log units) below it, within the range that was stated.
By their numbers in this assay, from the lowest: compounds 2 and 4 (each within the scatter of the next); then compound 3. At a limit, below all of these: compound 1.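

In this assay the change to methyl on the sulfonyl sulfur gives a 6.6-fold lower number from compound 3 to compound 4 (0.82 log units; beyond the scatter), so a low number here does not need a sulfonamide nitrogen. Methyl and isopropylamino are not told apart, with a 1.5-fold higher number from compound 2 to compound 4 (0.18 log units; within the scatter). Against (2-methoxyethyl)amino only a floor can be read, an at least 1.8-fold higher number from compound 1 to compound 4 (0.25 log units; that floor lies within the scatter), because compound 1 stands at a limit and not at a number: the limit of < 10 mL.min-1.g-1 in this assay, at which 1 of the 4 values shown sits.

As far as these compounds go, it remains open whether the high number of compound 3 goes with the isobutyl chain or with the methyl on its nitrogen. A dimethylamino group or an unbranched butylamino group on the sulfonyl sulfur would help separate the two.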